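A Longer Linker on the Three-Membered Ring

The source may report more compounds than this note shows. Statements on the series, on what has been measured and on what is new or still open speak of the compounds shown alone.

compound 1 (`CCN1CCc2c(sc(NC(=O)C3(c4ccc(Cl)cc4)CC3)c2C(N)=O)C1`) > 25000 nM
compound 2 (`CCN1CCCc2c(sc(NC(=O)Nc3ccc(Cl)cc3)c2C(N)=O)C1`) 3980 nM

In a functional assay (strain AB) with Danio rerio as the target, read by microscopy, with a stated time of 1 h (on this read-out higher numbers stand for an effect only at larger amounts of compound and lower numbers for an effect already at smaller amounts), compound 1 gives > 25000 nM as a limit of the assay and not a number. Compound 3 (`CCN1CCc2c(sc(NC(=O)C3(C(=O)Nc4ccc(Cl)cc4)CC3)c2C(N)=O)C1`) has (4-chlorophenyl)carbamoyl in place of 4-chlorophenyl on a saturated ring carbon. Within the data shown here, no measured pair shows this change. Among the measured compounds shown here, compound 2 gives 3980 nM as a true number in this assay and so offers the only guide. A moderate expected step toward lower numbers (an at least 2.0-fold lower number from compound 1 to compound 3 (0.31 log units; beyond the scatter)) seems likely, though another limit remains possible. Compound 3 is estimated at 12000 nM with an expected range from 3000 nM to 40000 nM in this estimate.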

Compound 3, half-maximal effective concentration: > 25000 nM
Compound 3 was reported as a limit (the forecaster's own chance of this, stated with the estimate: 40%); middle value at least 2.0-fold (0.31 log units) away from the limit.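

Compound 1 and compound 3 both give a limit and not a number, so no step can be read between them: the limit of > 25000 nM in this assay, at which 2 of the 3 values shown sit. From the compounds shown here alone, whether (4-chlorophenyl)carbamoyl in place of 4-chlorophenyl changes the effect at all stays open.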